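Nitro in Place of Bromo on the Aniline Ring

The compounds below may be only part of what the source reports. "The series", "measured", "known", "first", "only" and "open" are said of these compounds alone.

Compound 2 `C=CC(=O)Nc1cccc(NC(=O)CSc2nc(Nc3cccc(Br)c3)c3ccccc3n2)c1` gives 15000 nM in a functional assay on PC-3 cells (Homo sapiens) for inhibition, read by MTT assay, with a stated time of 72 h; on this read-out higher numbers stand for weaker inhibition and lower numbers for stronger inhibition. Compound 1 `C=CC(=O)Nc1cccc(NC(=O)CSc2nc(Nc3ccccc3Br)c3ccccc3n2)c1` gives 17100 nM in this assay, and a 1.1-fold lower number from compound 1 to compound 2 (0.06 log units; within the scatter). The two numbers therefore sit within the scatter of each other, so no ordering can be read from them. Compound 3 `C=CC(=O)Nc1cccc(NC(=O)CSc2nc(Nc3cccc([N+](=O)[O-])c3)c3ccccc3n2)c1` has not been measured; it differs from compound 2 by nitro in place of bromo on an aromatic carbon. For the measured compounds named here, the single measured step only moves a bromo around the ring and does not bear on exchanging it for nitro, so no shift beyond the scatter is expected, no change at the digits printed from compound 2 to compound 3 (within the scatter). Compound 3 is thus estimated at 15000 nM, with a range from 5000 nM to 45000 nM.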

Compound 3, half-maximal inhibitory concentration: 46300 nM
Compound 3: middle estimate off by 3.1-fold (0.49 log units), on the low side; the whole stated range lies below it.
By their numbers in this assay, from the lowest: compounds 2 and 1 (each within the scatter of the next); then compound 3.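

Compounds 1 and 2, which carry bromo in two different places, could not be told apart, but this position does respond to the group it carries: nitro in place of bromo gives a 3.1-fold higher number from compound 2 to compound 3 (0.49 log units; beyond the scatter), meaning weaker inhibition. The 3-nitrophenyl group also compares poorly with the 2-bromophenyl group, with a 2.7-fold higher number from compound 1 to compound 3 (0.43 log units; beyond the scatter). No available evidence gives a reason for this weakening.

The compounds shown leave open how an amine or a methoxy group would fare at this place. They also leave open whether nitro elsewhere on the aniline ring would give the same result.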